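A Carbamate on the Aromatic Oxygen of Compound 2

The source may report more compounds than this note shows. Statements on the series, on what has been measured and on what is new or still open speak of the compounds shown alone.

Of the compounds shown here, three sharing one core have been measured in a functional assay on PANC-1 cells (Homo sapiens) for inhibition, read by MTT assay, with a stated time of 24 h, tested at 10 uM; a higher number here means more inhibition at the concentration tested (going by the name of the read-out), a lower number less inhibition. Compound 1 `CC(C)=CCC1Cc2c(O)cc(=O)n(CCCO)c2CC1(C)C` gives 0% in this assay. Compound 2 `CC(C)=CCC/C(C)=C/CC1Cc2c(O)cc(=O)n(CCCO)c2CC1(C)C` gives 0%, and the step of no change at the digits printed from compound 1 to compound 2 (within the scatter), so compound 2 stands level with compound 1 at the digits shown, the two together being the lowest of the three numbers. Compound 3 `CC(C)=CCC1Cc2c(OCCCNC(=O)c3cccs3)cc(=O)n(CCCO)c2CC1(C)C` gives 5.6%, the highest number shown, although the step of a number 5.6 percentage points higher from compound 1 to compound 3 (within the scatter), so nothing beyond the scatter separates it from the other two.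

Compound 4 `CC(C)=CCC/C(C)=C/CC1Cc2c(OC(=O)Nc3ccc(F)c(F)c3)cc(=O)n(CCCO)c2CC1(C)C` has not yet been measured in this assay. It differs from compound 2 in one place: (3,4-difluorophenyl)carbamoyl in place of hydrogen on an oxygen on an aromatic ring.

Within the data shown here, the step that bears on this change is the one from compound 1 to compound 3, where the same oxygen likewise gained a group in place of hydrogen and the number moved within the scatter; the step from compound 1 to compound 2 shows that the chain at the other end of the core also left the number unchanged. Among the measured compounds shown here, no measured step here has moved beyond the scatter, so the step of a number 3 percentage points higher from compound 2 to compound 4 (within the scatter) is expected to stay within it. Compound 4 is therefore estimated at 3%, within a range from 0% to 15%.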

Compound 4, a percentage reported as inhibition, at one concentration (the size of the read-out at that concentration, not a potency): 4.8%
Beside the measured number, compound 4's estimate is 1.8 percentage points below it; low and high end bracket the measured number.
By their numbers in this assay, from the lowest: compounds 1, 2, 4 and 3 (each within the scatter of the next).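

With the longer chain of compound 2 in place, the change from hydroxy to ((3,4-difluorophenyl)carbamoyl)oxy adds 11 heavy atoms, including one six-membered aromatic ring, on the oxygen on an aromatic ring, and in this assay it gives a number 4.8 percentage points higher from compound 2 to compound 4 (within the scatter). This oxygen has now taken a large group on two different chains at the other end of the core: a carbamate here and, earlier, an amide-bearing chain with a number 5.6 percentage points higher from compound 1 to compound 3 (within the scatter), so neither group has moved the number beyond the scatter. No accompanying measurement addresses why this large addition leaves the number within the scatter.

The compounds shown leave open whether a group of another kind on this oxygen, such as a chain ending in an amine or a carboxylic acid, would move the number beyond the scatter. They also leave open whether the two fluorines of the carbamate matter, which a plain phenylcarbamoyl group on the same oxygen of compound 2 would test directly, and how any of these compounds behaves at a higher concentration.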